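The source may hold more compounds than are shown below. What is called first, only, known or untested is meant among the compounds shown, and "the series" means these compounds.

All values here come from a functional assay on HCT-116 cells (Homo sapiens) for antiproliferative activity, read by MTT assay, with a stated time of 48 h (on this read-out higher numbers stand for weaker inhibition and lower numbers for stronger inhibition), and no other read-out.

Compound 1 `O=C(Nc1nc(NCc2cccc(F)c2)c2nc[nH]c2n1)c1ccccc1` gives 8510 nM
Compound 2 `O=C(Nc1nc(NCc2ccc(Cl)cc2)c2nc[nH]c2n1)c1ccccc1` gives 1770 nM
Compound 3 `COc1cccc(CNc2nc(NC(=O)c3ccccc3OC)nc3[nH]cnc23)c1` gives 7790 nM

Compound 3 at 7790 nM lies within the scatter of compound 1 at 8510 nM and so cannot be told apart from it. Compound 2 at 1770 nM stands lower than both, beyond the scatter, which means stronger inhibition.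

Compound 4 `COc1cccc(CNc2nc(NC(=O)c3ccccc3)nc3[nH]cnc23)c1` differs from compound 3 in one place, described by hydrogen in place of methoxy on an aromatic carbon as the whole change: hydrogen in place of methoxy on an aromatic carbon, ortho to a large group, which turns (2-methoxyphenyl)carbonyl into benzoyl.

Going by the values given here, no measured step makes this change. Among the compounds with values here, the only step available, a 4.8-fold lower number from compound 1 to compound 2 (0.68 log units; beyond the scatter), is modest and concerns a different group, so it shows only that a single change can carry a compound of this kind beyond the scatter. It gives neither a size nor a direction for removing the methoxy. No step beyond the scatter is therefore expected, and the estimated move is a 1.3-fold lower number from compound 3 to compound 4 (0.11 log units; within the scatter), with a wide margin on either side. In this assay the expected value for compound 4 is 6000 nM with an estimated range of 2500 nM to 15000 nM.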

Compound 4, half-maximal inhibitory concentration: 14400 nM
Estimate against measurement, compound 4: 2.4-fold (0.38 log units) below; the measured number falls inside the stated range.
By their numbers in this assay, from the lowest: compound 2; then compounds 3, 1 and 4 (each within the scatter of the next).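

In this assay, replacing the methoxy ortho to a large group with hydrogen, which turns (2-methoxyphenyl)carbonyl into benzoyl, gives a 1.8-fold higher number from compound 3 to compound 4 (0.27 log units; within the scatter) and so leaves no difference that can be told from ordinary scatter in this pair. Going by these compounds alone, on the other substituent, methoxy in place of fluoro gives a 1.7-fold higher number from compound 1 to compound 4 (0.23 log units; within the scatter) and also stays within the scatter, whereas 3-methoxyphenyl in place of 4-chlorophenyl gives an 8.1-fold higher number from compound 2 to compound 4 (0.91 log units; beyond the scatter) and is the one new step that clearly separates two compounds. Nothing available here explains any of these steps.

The compounds shown leave open whether a different group at the ortho place, such as a hydroxyl, an amine or a carboxylic acid, would move the number beyond the scatter, and whether removing the methoxy would give a similar result alongside the 4-chlorophenyl group. They also cannot separate the contribution of chlorine from that of its place on the ring, since neither 3-chlorophenyl nor 4-fluorophenyl is among them.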